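Phenyl for benzyloxy: working notes on the series

The compounds below may be only part of what the source reports. "The series", "measured", "known", "first", "only" and "open" are said of these compounds alone.

Of the compounds shown here, three have values so far in an ADME assay on microsomes from liver (Homo sapiens), read by LC-MS, using NADPH, with a stated time of 10 min, tested at 0.5 uM; a lower number here means that less of the compound is left, a higher number that more of the compound is left. Compound 1 `Cc1nc2cc(-c3ccccc3)nn2c(N2CCC(C)(C)CC2)c1C(OC(C)(C)C)C(=O)O` gives 100%, compound 2 `Cc1nc2cc(-c3ccc(OCc4ccccc4)cc3)nn2c(-c2cc(F)c3c(c2C)CCCO3)c1C(OC(C)(C)C)C(=O)O` gives 84% and compound 3 `Cc1nc2cc(-c3cccc(OCc4ccccc4)c3)nn2c(-c2cc(F)c3c(c2C)CCCO3)c1C(OC(C)(C)C)C(=O)O` gives 72%. Compound 3 is therefore the lowest of the three, beyond the usual scatter from both others, and compound 2 is its nearest neighbour.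

Compound 4 `Cc1nc2cc(-c3cccc(-c4ccccc4)c3)nn2c(-c2cc(F)c3c(c2C)CCCO3)c1C(OC(C)(C)C)C(=O)O` has phenyl in place of benzyloxy on an aromatic carbon, meta to a large group (phenyl in place of benzyloxy on an aromatic carbon). Going by the values given here, no measured pair differs in one place only, so this change has no direct precedent. The closest guide is compound 2, which also carries benzyloxy and gives 84%, while compound 3 gives 72%. A modest change is therefore more likely than a large one. The expected step of a number 7 percentage points higher from compound 3 to compound 4 (within the scatter) is small and upward, and it may not clear the scatter. For compound 4 the estimated value in this assay is 79%, with an expected range of 62% to 97%.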

Compound 4, percent of the compound remaining: 86%
The estimate for compound 4 lay 7 percentage points below the measured number; the measured number falls inside the stated range.
By their numbers in this assay, from the lowest: compound 3; then compounds 2 and 4 (each within the scatter of the next); then compound 1.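

Going by these compounds alone, this is the first comparison that differs in one place only. In this assay, phenyl in place of benzyloxy on an aromatic carbon, meta to a large group, gives a number 14 percentage points higher from compound 3 to compound 4 (beyond the scatter), so this position responds to the change by more than the usual scatter, and more of the compound is left with phenyl. Nothing available bears on why the number moves, and the step stands as an observation only.

Within the data shown here, the single step does not separate the loss of the oxygen, the only hydrogen-bond acceptor in benzyloxy, from the loss of the link between the two aromatic rings. Also open, on these data alone, is how a small group such as methoxy or a nitrile would read at this place, and whether the same replacement gives a similar step elsewhere on the ring.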